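Moving a Chlorine Around the Pendant Ring

This account rests on a few compounds, and the source may have more. Where it says the series, first, only, none or still open, it means among the compounds named here.

Compound 3 `O=C(O)CCC(=O)N1N=C(c2c(-c3ccc(Cl)c(Cl)c3)c3ccccc3[nH]c2=O)CC1c1ccc(Cl)cc1` gives 910 nM in an assay on cells (Oocyte) for negative allosteric modulation of glutamate receptor ionotropic, NMDA 2D (Rattus norvegicus), read by two-electrode voltage clamp (a lower number here means a stronger inhibitor, a higher number a weaker inhibitor), the second highest of the three numbers measured. Compound 1 `O=C(O)CCC(=O)N1N=C(c2c(-c3ccc(Br)cc3)c3ccccc3[nH]c2=O)CC1c1ccc(Cl)cc1` gives 290 nM in this assay, and compound 2 `O=C(O)CCC(=O)N1N=C(c2c(-c3cccc(C(F)(F)F)c3)c3ccccc3[nH]c2=O)CC1c1ccc(Cl)cc1` gives 2600 nM. The steps of a 3.1-fold higher number from compound 1 to compound 3 (0.50 log units; beyond the scatter) and a 9.0-fold higher number from compound 1 to compound 2 (0.95 log units; beyond the scatter) both raised the number, while a 2.9-fold lower number from compound 2 to compound 3 (0.46 log units; beyond the scatter) lowered it. Compound 4 `O=C(O)CCC(=O)N1N=C(c2c(-c3cc(Cl)cc(Cl)c3)c3ccccc3[nH]c2=O)CC1c1ccc(Cl)cc1` differs from compound 3 by 3,5-dichlorophenyl in place of 3,4-dichlorophenyl on an aromatic carbon. Because the 3-(trifluoromethyl)phenyl of compound 2 carried the weakest result, 2600 nM, a pendant ring substituted only at the 3- and 5-positions is expected to raise the number modestly. Compound 4 is therefore expected to give 1800 nM, within a range of 700 nM to 4500 nM. The expected step is a 2.0-fold higher number from compound 3 to compound 4 (0.30 log units; within the scatter).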

Compound 4, half-maximal inhibitory concentration: 700 nM
Compound 4: the middle estimate sits 2.6-fold (0.41 log units) above what was measured; measured number inside the range.
By their numbers in this assay, from the lowest: compound 1; then compounds 4 and 3 (each within the scatter of the next); then compound 2.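

In this assay, swapping 3,4-dichlorophenyl for 3,5-dichlorophenyl gives a 1.3-fold lower number from compound 3 to compound 4 (0.11 log units; within the scatter), so this position accepts either arrangement of the two chlorines without a change that can be told from the scatter. The 3,5-dichlorophenyl still differs from the other two groups, with a 3.7-fold lower number from compound 2 to compound 4 (0.57 log units; beyond the scatter) and a 2.4-fold higher number from compound 1 to compound 4 (0.38 log units; beyond the scatter). Nothing available explains these differences.

On these data alone, whether a single chlorine, as in 4-chlorophenyl, would match the 4-bromophenyl of compound 1 remains open. So does the effect of a methoxy group or an amine on this ring.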